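The source may report more compounds than this note shows. Statements on the series, on what has been measured and on what is new or still open speak of the compounds shown alone.

Compound 1 `CC(=O)N1N=C(c2ccc3ccccc3c2)OC1c1cccc(F)c1`: 1.98 ug/mL
Compound 2 `CC(=O)N1N=C(c2ccc3ccccc3c2)OC1c1ccc2ccccc2c1`: 1.01 ug/mL

For the measured compounds named here, in a functional assay on MCF7 cells (Homo sapiens) for antiproliferative activity, read by MTT assay, with a stated time of 48 h (on this read-out lower numbers stand for stronger inhibition and higher numbers for weaker inhibition), compound 1 gives 1.98 ug/mL and so stands within the scatter of compound 2 at 1.01 ug/mL on the only two numbers available so far. Compound 3 `CC(=O)N1N=C(c2ccc3ccccc3c2)OC1c1ccc(C)cc1` has not yet been measured. Compared with compound 1 it carries 4-methylphenyl in place of 3-fluorophenyl on a saturated ring carbon with 4-methylphenyl in place of 3-fluorophenyl on a saturated ring carbon. Going by the values given here, no measured pair shows this change, so no step beyond the scatter is expected in this assay in either direction. The expected change is a 1.2-fold lower number from compound 1 to compound 3 (0.07 log units; within the scatter) on this estimate. Compound 3 is estimated at 1.7 ug/mL with an expected range from 0.7 ug/mL to 4.5 ug/mL in this read-out.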

Compound 3, half-maximal inhibitory concentration: 2.9 ug/mL
Estimate against measurement, compound 3: 1.7-fold (0.23 log units) below, and the stated range covers the measured number.
By their numbers in this assay, from the lowest: compounds 2, 1 and 3 (each within the scatter of the next, the first and the last beyond it).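

In this assay, 4-methylphenyl in place of 3-fluorophenyl on the saturated ring carbon gives a 1.5-fold higher number from compound 1 to compound 3 (0.17 log units; within the scatter), the first step read at this position. This exchange alters both the substituent and where it sits on the phenyl ring, yet the read-out does not move beyond the scatter. No supporting measurement bears on this result. The compounds shown leave open whether fluorine and methyl would compare in the same way at one shared place on the phenyl ring. They also leave open whether an amine or a carboxylic acid there would move the number further.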